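Benzyloxy in Place of Trifluoromethyl on the Benzyl Arm

A few compounds are considered here, and "the series" means these few. Any claim that something is new, unique, unknown or untested is made for them only; others in the source may bear on it.

Compound 1 `Cc1cc(=O)c(O)c(Cc2ccc(F)cc2)o1`: > 50000 nM
Compound 2 `Cc1cc(=O)c(O)c(Cc2ccc(Cl)cc2)o1`: > 50000 nM
Compound 3 `Cc1cc(=O)c(O)c(Cc2ccc(C(F)(F)F)cc2)o1`: 24400 nM

Of the compounds shown here, three sharing one core have been tested in a functional assay on HT-1080 cells (Homo sapiens) for antiproliferative activity, read by MTT assay; on this read-out higher numbers stand for weaker inhibition and lower numbers for stronger inhibition. Compound 1 gives > 50000 nM, which is a limit of the assay and not a number. Compound 2 likewise gives > 50000 nM, again a limit. Among the compounds with values here, compound 3 is the only one with a number in this assay, 24400 nM, and so stands as the sole measured point; two of the three values sit at the limit of > 50000 nM in this assay, at which 2 of the 3 values shown sit.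

Of the steps between them, a step that the two limits leave unreadable from compound 1 to compound 2, while an at least 2.0-fold lower number from compound 1 to compound 3 (0.31 log units; beyond the scatter) and an at least 2.0-fold lower number from compound 2 to compound 3 (0.31 log units; beyond the scatter). All three steps exchange one small group on the aromatic carbon.

Compound 4 `Cc1cc(=O)c(O)c(Cc2ccc(OCc3ccccc3)cc2)o1` differs from compound 3 as follows: benzyloxy in place of trifluoromethyl on an aromatic carbon. Within the data shown here, no measured step swaps a small group for a larger one of this kind, so the measured steps give no direct reading of its size. The account expects a step of a 1.6-fold lower number from compound 3 to compound 4 (0.21 log units; within the scatter) for compound 4 in this assay, with wide uncertainty. Compound 4 is therefore estimated at 15000 nM, between 4000 nM and 50000 nM.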

Compound 4, half-maximal inhibitory concentration: > 50000 nM
Compound 4: no number, only a limit; the forecaster's own chance of this, stated with the estimate: 25%; middle value at least 3.3-fold (0.52 log units) away from the limit.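

In this assay compound 4 gives > 50000 nM, which is a limit of the assay and not a number. Benzyloxy in place of trifluoromethyl brings an at least 2.0-fold higher number from compound 3 to compound 4 (0.31 log units; beyond the scatter), so the number seen at this position with trifluoromethyl does not carry over to a group that adds a second six-membered aromatic ring. The steps to compound 4 from compound 1 and from compound 2 cannot be read, and compound 3 remains the only one of the four with a number: the limit of > 50000 nM in this assay, at which 3 of the 4 values shown sit.

The compounds shown leave open whether the oxygen or the added ring of benzyloxy goes with this step, which methoxy or an unlinked phenyl group could separate. They also leave open whether an amine or a carboxylic acid on this aromatic carbon would give a number at all.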